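Changing the Aryl Group on the Weakest Compound

The source may hold more compounds than are shown below. What is called first, only, known or untested is meant among the compounds shown, and "the series" means these compounds.

Measured so far in a functional assay on PC-3 cells (Homo sapiens) for antiproliferative activity, read by MTT assay, tested at 1 uM; a lower number here means a weaker effect, a higher number a stronger effect of the compound at the concentration tested:
compound 1, `COc1cc(C(=O)N/N=C/c2ccccc2F)cc(OC)c1OC`, gives 70.6%
compound 2, `COc1cc(C(=O)N/N=C/c2ccc(C(F)(F)F)cc2)cc(OC)c1OC`, gives 59.9%
compound 3, `COc1cc(C2=NN(C(C)=O)C(c3ccccc3F)O2)cc(OC)c1OC`, gives 13.5%

Compound 3 stands lowest of the three numbers. Its nearest neighbour is compound 2, whose value lies higher by an amount beyond the scatter, and compound 1 lies higher still, also beyond the scatter. The two higher values belong to the open-chain acylhydrazones, while compound 3 carries the ring-closed core with an acetyl group, and that core alone accompanies a weak effect.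

Compound 4, `COc1cc(C2=NN(C(C)=O)C(c3ccc(Cl)c(Cl)c3)O2)cc(OC)c1OC`, keeps this core of compound 3 and differs in one place: 3,4-dichlorophenyl in place of 2-fluorophenyl on a saturated ring carbon. Within the data shown here, no step between two measured compounds isolates such a change, so no measured reference exists for it. Among the measured compounds shown here, the only guidance is the low value of compound 3 itself.

The step of a number 6.5 percentage points higher from compound 3 to compound 4 (within the scatter) is therefore expected to be small, within the scatter, with no clear direction. On that basis compound 4 is estimated to give 20%, with the likely range running from 5% to 45%.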

Compound 4, a percentage reported as inhibition, at one concentration (the size of the read-out at that concentration, not a potency): 28.1%
The estimate for compound 4 lay 8.1 percentage points below the measured number; the measured number falls inside the stated range.
By their numbers in this assay, from the lowest: compound 3; then compound 4; then compound 2; then compound 1.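

In this assay the aryl group on the saturated ring carbon of this acetylated core is shown to matter: 3,4-dichlorophenyl in place of 2-fluorophenyl gives a number 14.6 percentage points higher from compound 3 to compound 4 (beyond the scatter), the first single-place step available here and one that lies beyond the scatter. The position therefore responds to a change of aryl group, though only modestly, and compound 4 still gives only 28.1% at the concentration tested. The exchange removes one fluorine, brings in two chlorines and moves the substitution on the aromatic ring all at once, so this one pair cannot separate those changes, and no measurement shown here accounts for the step.

The compounds shown leave open whether a single chlorine, a plain phenyl, or a methoxy or amine group on the aromatic ring would shift the value at this carbon further, and how far the value would move in either direction. They also leave open whether the same aryl exchange would act alike if the acetyl group gave way to a longer acyl chain or a simple hydrogen on the ring nitrogen.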